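The source may report more compounds than this note shows. Statements on the series, on what has been measured and on what is new or still open speak of the compounds shown alone.

Measured compounds:
Compound 1, `CCCCCOc1ccc(-c2c(C)[nH]c(=O)n2C)cc1`, gives 4500 nM in a functional assay on brain (Rattus norvegicus, strain Wistar) for inhibition; a higher number here means a weaker inhibitor, a lower number a stronger inhibitor.
Compound 2, `CCCCCCCCc1ccc(-c2c(C)[nH]c(=O)n2C)cc1`, gives 19400 nM in this assay.
Compound 3, `CCCCCOc1ccc(-c2c(C)[nH]c(=O)n2C2CCCCC2)cc1`, gives 9100 nM in this assay.

Among these three, compound 3 stands second highest in this assay, with compound 1 giving a lower number and compound 2 a higher one. Going by the values given here, the one single-point step that connects two measured compounds runs from compound 1 to compound 3: a 2.0-fold higher number from compound 1 to compound 3 (0.31 log units; beyond the scatter). Compound 2 is not joined to compound 1 or compound 3 by a single change, so its value shows only that a long chain directly on the ring goes with a higher number than the pentyloxy chain of compound 1.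

Compound 4, `Cc1[nH]c(=O)n(C2CCCCC2)c1-c1ccc(OCc2ccccc2)cc1`, has not been measured. It differs from compound 3 in one place: phenyl in place of butyl on a saturated chain carbon bound to an oxygen on an aromatic ring. Among the compounds with values here, no measured step touches this part of the molecule, since the one known step alters the group on the aromatic nitrogen instead. There is therefore no basis in the data for expecting a change beyond the scatter in this assay, in either direction. The step from compound 3 to compound 4 is thus estimated as a 1.1-fold lower number from compound 3 to compound 4 (0.03 log units; within the scatter). Compound 4 is expected to give about 8500 nM in this assay, with a range from 3000 nM to 25000 nM.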

Compound 4, half-maximal inhibitory concentration: 8300 nM
Compound 4: middle estimate off by 1.0-fold (0.01 log units), on the high side, and the stated range covers the measured number.
By their numbers in this assay, from the lowest: compounds 1, 4 and 3 (each within the scatter of the next, the first and the last beyond it); then compound 2.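

Replacing the pentyloxy chain with benzyloxy, the first change shown at this end of the molecule, gives a 1.1-fold lower number from compound 3 to compound 4 (0.04 log units; within the scatter) in this assay and so leaves the number within the scatter. On a saturated chain carbon bound to an oxygen on an aromatic ring, a butyl can therefore give way to a phenyl, with two more heavy atoms and a six-membered aromatic ring, without a readable change, at least in compounds that carry cyclohexyl on the aromatic nitrogen. Nothing measured here explains why these two groups give such similar numbers.

As far as these compounds go, it remains open whether benzyloxy would behave the same way with methyl in place of cyclohexyl on the aromatic nitrogen, as in compound 1. Also open, from the compounds shown here alone, is whether an amine or a carboxylic acid on that chain carbon, or a longer chain in place of butyl, would shift the number beyond the scatter in either direction.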